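The source may report more compounds than this note shows. Statements on the series, on what has been measured and on what is new or still open speak of the compounds shown alone.

In an ADME assay on L6 cells (Rattus norvegicus) for cytotoxicity, read by fluorescence and resazurin assay, with a stated time of 72 h (on this read-out lower numbers stand for an effect already at smaller amounts and higher numbers for an effect only at larger amounts of compound), compound 1 `O=c1nc(-c2ccccc2)c2cc(-c3cccc(F)c3)ccc2[nH]1` gives 23000 nM. Compound 2 `O=c1nc(-c2ccccc2)c2cc(-c3cc[nH]n3)ccc2[nH]1` gives > 50000 nM, which is a limit of the assay and not a number, so it can be placed only at that limit. Compound 3 `O=c1nc(-c2ccccc2)c2cc(-c3cn[nH]c3)ccc2[nH]1` has the same atoms as compound 2, joined differently: 1H-pyrazol-4-yl in place of 1H-pyrazol-3-yl on an aromatic carbon. The change sits on an aromatic carbon of the shared core. For the measured compounds named here, only one measured step bears on it, an at least 2.1-fold higher number from compound 1 to compound 2 (0.33 log units; beyond the scatter), which lies beyond the scatter and is at least modest, but it replaces a different group. Going by the values given here, with compound 2 known only as a limit and that step as the sole guide, no step beyond the scatter is expected in this assay. The expected change is an at least 1.1-fold lower number from compound 2 to compound 3 (0.04 log units; that floor lies within the scatter). For compound 3 the estimated value is 45000 nM, with an expected range of 20000 nM to 90000 nM.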

Compound 3, half-maximal effective concentration: > 50000 nM
Compound 3 was reported as a limit; the forecaster's own chance of this, stated with the estimate: 55%; middle value at least 1.1-fold (0.04 log units) away from the limit.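

In this assay, replacing 3-fluorophenyl with 1H-pyrazol-4-yl gives an at least 2.1-fold higher number from compound 1 to compound 3 (0.33 log units; beyond the scatter), so the higher number no longer rests on 1H-pyrazol-3-yl alone. Compound 3 gives > 50000 nM, which is a limit of the assay and not a number. The step between compound 2 and compound 3 cannot be read, because both compounds sit at that limit: the limit of > 50000 nM in this assay, at which 2 of the 3 values shown sit.

Going by these compounds, how far past the limit compound 2 and compound 3 lie stays open, and with it whether moving the attachment of the pyrazole ring changes anything in this assay. Also open, on these data alone, is whether an amine, a carboxylic acid or an unsubstituted phenyl on this aromatic carbon would give a value that can be read as a number.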